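A few compounds are considered here, and "the series" means these few. Any claim that something is new, unique, unknown or untested is made for them only; others in the source may bear on it.

Measured compounds:
compound 1 `COC(=O)C1=C(C)NC(C)=C(C(=O)OC)C1c1cnc(SC)n1Nc1ccccc1` — 3.54 nM
compound 2 `CCCOC(=O)C1=C(C)NC(C)=C(C(=O)OCCC)C1c1cnc(SC)n1Nc1ccccc1` — 2.29 nM
compound 3 `CCOC(=O)C1=C(C)NC(C)=C(C(=O)OC)C1c1cnc(SC)n1Nc1ccccc1` — 1.66 nM

All three share one core and differ only in the two ester chains. In an assay on isolated protein (strain albino) for antagonist activity at Voltage-dependent L-type calcium channel subunit alpha-1C (Cavia porcellus) (on this read-out lower numbers stand for stronger inhibition and higher numbers for weaker inhibition), compound 3 gives the lowest of the three numbers. Its nearest neighbour is compound 2, whose value sits within the scatter of it, so no order between those two can be read; compound 1 stands furthest away, and the step of a 2.1-fold lower number from compound 1 to compound 3 (0.33 log units; beyond the scatter) lies beyond the scatter.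

Compound 4 `CCCOC(=O)C1=C(C)NC(C)=C(C(=O)OC)C1c1cnc(SC)n1Nc1ccccc1` has not been measured in this assay. It differs from compound 3 by methyl in place of hydrogen on a saturated chain carbon, two bonds along the chain from an oxygen next to a carbonyl group, that is, the ethyl ester of compound 3 grows into a propyl ester while the methyl ester on the other side is kept.

Within the data shown here, only one measured step speaks to this: the step from compound 1 to compound 3, where the same kind of addition, one bond closer to the oxygen, produced the modest drop just quoted. Beyond that, compound 2 shows that carrying propyl on both esters gives a number that is not separable from compound 3 within the scatter. A further lengthening is therefore expected to move the number little, if at all, in this assay.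

The estimate for compound 4 is 1.6 nM, within a range of 0.8 nM to 3.2 nM, which means an expected step of a 1.0-fold lower number from compound 3 to compound 4 (0.02 log units; within the scatter).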

Compound 4, half-maximal inhibitory concentration: 2.4 nM
Compound 4: middle estimate off by 1.5-fold (0.18 log units), on the low side; the measured number falls inside the stated range.
By their numbers in this assay, from the lowest: compounds 3, 2, 4 and 1 (each within the scatter of the next, the first and the last beyond it).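

In this assay, turning the ethyl ester into a propyl ester, a methyl added on the saturated chain carbon two bonds along the chain from an oxygen next to a carbonyl group, gives a 1.4-fold higher number from compound 3 to compound 4 (0.16 log units; within the scatter), so this added carbon leaves no readable mark on the number. Cutting one of the two propyl esters back to a methyl ester gives a 1.0-fold higher number from compound 2 to compound 4 (0.02 log units; within the scatter), so changing the chain on that side cannot be read either. Among these compounds, measured against the methyl ester, the single propyl ester gives a 1.5-fold lower number from compound 1 to compound 4 (0.17 log units; within the scatter), whereas the ethyl ester gave a 2.1-fold lower number from compound 1 to compound 3 (0.33 log units; beyond the scatter), so the one step beyond the scatter does not continue as a clear trend when the chain grows by another carbon.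

Going by these compounds, whether a longer chain such as a butyl ester, or a chain ending in an amine or a carboxylic acid, would stay in this narrow range remains open. Nothing beyond these numbers is available to explain why the ethyl and propyl esters fall so close together.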